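Benzylpurine series: a second chloro on the core

The source may report more compounds than this note shows. Statements on the series, on what has been measured and on what is new or still open speak of the compounds shown alone.

Compound 1, `ClCc1ccc(Cn2cnc3c(Cl)ncnc32)cc1`, in a functional assay on NCI-H522 cells (Homo sapiens) for cytotoxicity, read by sulforhodamine B assay, with a stated time of 48 h (a higher number here means a weaker inhibitor of growth, a lower number a stronger inhibitor of growth), gives only a limit, > 100000 nM.
Compound 2, `ClCc1ccccc1Cn1cnc2ncnc(Cl)c21`, gives 75900 nM in this assay.
Compound 3, `ClCc1ccc(Cn2cnc3c(Cl)nc(Cl)nc32)cc1`, gives 46800 nM in this assay.

Compound 1 and compound 2 have the same atoms joined differently; the difference between the two cores is not broken down here. Their values show compound 2 with a number where compound 1 gives only a limit. Compound 2 and compound 3 lie within the scatter of each other, so no order between them is read.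

Among the measured compounds shown here, the one measured step is chloro in place of hydrogen on an aromatic carbon. It gives an at least 2.1-fold lower number from compound 1 to compound 3 (0.32 log units; beyond the scatter). Because the limit of > 100000 nM in this assay, at which 1 of the 3 values shown sits, sits at the start of that step, its size is known only as a lower bound.

The unmeasured compound 4, `ClCc1ccccc1Cn1cnc2nc(Cl)nc(Cl)c21`, differs from compound 2 by chloro in place of hydrogen on an aromatic carbon. The place of the change is the same word for word as in the step from compound 1 to compound 3, so it is the same change carried onto the other core. The step is expected to be a 3.0-fold lower number from compound 2 to compound 4 (0.48 log units; beyond the scatter); this rests on an at least 2.1-fold lower number from compound 1 to compound 3 (0.32 log units; beyond the scatter), taken as open upward because the limit of > 100000 nM in this assay, at which 1 of the 3 values shown sits, hides how far compound 1 really lies. Compound 4 is therefore estimated at 25000 nM, with a range from 8000 nM to 60000 nM expected.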

Compound 4, concentration for total growth inhibition: 7240 nM
Compound 4: the middle estimate sits 3.5-fold (0.54 log units) above what was measured, and the stated range ends above it.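

The direction of the change carries across both cores shown: in this assay, chloro in place of hydrogen on an aromatic carbon, between two ring nitrogen atoms, gives a lower number each time, and on the core of compound 2 the step is large, a 10-fold lower number from compound 2 to compound 4 (1.02 log units; beyond the scatter). Set side by side, the two steps give a result that holds for these two pairs only and offers no rule for the wider series: the same change on two cores in this assay, an at least 2.1-fold lower number (0.32 log units; beyond the scatter) from compound 1 to compound 3 and a 10-fold lower number (1.02 log units; beyond the scatter) from compound 2 to compound 4; the limit leaves it open whether they differ. The data do not show whether the size of the step carries over, since the start of the other step is a limit and not a number: the limit of > 100000 nM in this assay, at which 1 of the 4 values shown sits.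

The compounds shown leave open whether the effect belongs to chloro itself, as an amine, a methoxy group or a fluoro group on the same ring carbon would test, and whether it survives with a hydroxymethyl group in place of the chloromethyl group on the benzyl ring. They also leave open whether the large step seen in this assay appears in other cell lines, as all values here come from a single one.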